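Ethoxy in Place of Dimethylaminophenyl on the Imine Carbon

The source may hold more compounds than are shown below. What is called first, only, known or untested is meant among the compounds shown, and "the series" means these compounds.

Measured so far in a functional assay on Ehrlich cells (Mus musculus) for cytotoxicity, read by trypan blue exclusion, with a stated time of 2 h, tested at 50 ug/mL; a lower number here means a weaker effect, a higher number a stronger effect of the compound at the concentration tested:
Compound 1, `N#CC1=C(N)N(c2ccc(S(N)(=O)=O)cc2)C2=C(C(=O)CCC2)C1c1ccc(Cl)cc1Cl`, gives 65%.
Compound 2, `N#CC1=C(NC(=O)c2ccccc2)N(c2ccc(S(N)(=O)=O)cc2)C2=C(C(=O)CCC2)C1c1ccc(Cl)cc1Cl`, gives 70%.
Compound 3, `CN(C)c1ccc(/C=N/C2=C(C#N)C(c3ccc(Cl)cc3Cl)C3=C(CCCC3=O)N2c2ccc(S(N)(=O)=O)cc2)cc1`, gives 30%.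

Compound 3 stands lowest of the three numbers. Its nearest neighbour is compound 1, with a number 35 percentage points lower from compound 1 to compound 3 (beyond the scatter); the furthest is compound 2, with a number 40 percentage points lower from compound 2 to compound 3 (beyond the scatter). Between the other two, a number 5 percentage points higher from compound 1 to compound 2 (within the scatter) is small. Compound 4, `CCO/C=N/C1=C(C#N)C(c2ccc(Cl)cc2Cl)C2=C(CCCC2=O)N1c1ccc(S(N)(=O)=O)cc1`, differs from compound 3 by ethoxy in place of 4-(dimethylamino)phenyl on a carbon with a double bond to nitrogen. Within the data shown here, no measured step alters a group on the carbon with a double bond to nitrogen, so none bears directly on this change; the two large drops into compound 3 both concern the replacement of the amine itself, which compound 4 shares with compound 3. Compound 4 is therefore expected to stay close to compound 3, with a number 5 percentage points higher from compound 3 to compound 4 (within the scatter) within the scatter. Compound 4 is estimated at 35% in this assay, between 20% and 55%.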

Compound 4, a percentage reported as activity, at one concentration (the size of the read-out at that concentration, not a potency): 35%
Compound 4: the middle estimate sits on the measured number at the digits printed, and the stated range covers the measured number.
By their numbers in this assay, from the lowest: compounds 3 and 4 (each within the scatter of the next); then compounds 1 and 2 (each within the scatter of the next).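

In this assay, among these compounds, the result gives the first look at this position: a number 5 percentage points higher from compound 3 to compound 4 (within the scatter) shows that ethoxy and 4-(dimethylamino)phenyl on a carbon with a double bond to nitrogen are not told apart, so the aromatic ring is not required for the lower number. The low number also holds with either group, as a number 30 percentage points lower from compound 1 to compound 4 (beyond the scatter) and a number 35 percentage points lower from compound 2 to compound 4 (beyond the scatter) show. Nothing at hand explains this. On these data alone, whether a longer chain such as butoxy, or an amine or a carboxylic acid, on that carbon would leave the number unchanged stays open.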